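This account rests on a few compounds, and the source may have more. Where it says the series, first, only, none or still open, it means among the compounds named here.

In a functional assay on A2780 cells (Homo sapiens) for antiproliferative activity, read by MTT assay, with a stated time of 72 h (a lower number here means a stronger inhibitor of growth, a higher number a weaker inhibitor of growth), three compounds that share one core have been measured so far. Compound 1 `COc1cc(OC)c(/C=C/S(=O)(=O)Nc2ccc(Cl)cc2)c(OC)c1` with chloro on its aromatic ring gives > 10000 nM as a limit of the assay, not a number. Compound 2 `COc1ccc(NS(=O)(=O)/C=C/c2c(OC)cc(OC)cc2OC)cc1` with methoxy in that place gives 10 nM as an exact number. Compound 3 `CCOc1ccc(NS(=O)(=O)/C=C/c2c(OC)cc(OC)cc2OC)cc1` with ethoxy gives 310 nM and so holds the higher of the two exact numbers.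

The next compound is compound 4 `COc1cc(OC)c(/C=C/S(=O)(=O)Nc2cnc(Cl)cn2)c(OC)c1` and the change is 5-chloropyrazin-2-yl in place of 4-ethoxyphenyl on a sulfonamide nitrogen in which 5-chloropyrazin-2-yl comes in place of 4-ethoxyphenyl on a sulfonamide nitrogen. Among the measured compounds shown here, no measured step swaps the ring itself, so the closest guide is the chloro group that compound 4 has in common with compound 1. The step of an at least 32-fold lower number from compound 1 to compound 3 (1.50 log units; beyond the scatter) for ethoxy in place of chloro is large, and so is an at least 1000-fold lower number from compound 1 to compound 2 (3.00 log units; beyond the scatter) for methoxy in place of chloro. Even the small change in a 31-fold higher number from compound 2 to compound 3 (1.49 log units; beyond the scatter) is large. Read backwards, the first of these steps points to a large rise in the number, so the expected outcome is a 26-fold higher number from compound 3 to compound 4 (1.41 log units; beyond the scatter) and the assay may well report only its limit. For compound 4 the estimated value is 8000 nM with an expected range from 1500 nM to 40000 nM across repeat measurements.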

Compound 4, concentration for 50% growth inhibition: > 10000 nM
Compound 4 was reported as a limit; the forecaster's own chance of this, stated with the estimate: 55%; middle value at least 1.2-fold (0.09 log units) from the limit.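

In this assay, among the compounds shown here, this is the first change of the ring on the sulfonamide nitrogen rather than only of a group on it, and it gives an at least 32-fold higher number from compound 3 to compound 4 (1.50 log units; beyond the scatter) and an at least 1000-fold higher number from compound 2 to compound 4 (3.00 log units; beyond the scatter), so the low number of compound 2 does not survive the switch to 5-chloropyrazin-2-yl. Compound 4 is reported only as a limit, and it shares that limit with compound 1, the other chloro compound shown: the limit of > 10000 nM in this assay, at which 2 of the 4 values shown sit. For the compounds shown here, the step from compound 1 to compound 4 cannot be read with two limits at its ends, so the ring swap cannot be separated from the loss of the alkoxy group, and the two chloro compounds show only that neither gives a number within the range of the assay.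

On these data alone, it remains open whether the pyrazine ring itself is tolerated, which 5-methoxypyrazin-2-yl on the sulfonamide nitrogen would test directly against compound 2. Also open, as far as these compounds go, is how the sharp sensitivity seen so far extends to other groups in place of the methoxy of compound 2, such as an amine or a longer chain like propoxy.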